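Replacing 3-chlorophenyl in compound 1: working notes

The source may report more compounds than this note shows. Statements on the series, on what has been measured and on what is new or still open speak of the compounds shown alone.

Going by the values given here, in a functional assay on OVCAR-3 cells (Homo sapiens) for antiproliferative activity, read by MTT assay, with a stated time of 24 h (a lower number here means a stronger inhibitor, a higher number a weaker inhibitor), compound 1 (`O=C(NNc1cccc(Cl)c1)c1cccc(NS(=O)(=O)c2cnc(O)nc2O)c1`) gives 8040 nM, the only actual number so far. Compound 2 (`O=C(NNc1ccc(F)cc1)c1ccccc1NS(=O)(=O)c1cnc(O)nc1O`) is recorded at > 20000 nM, which is a limit and not a number.

Compound 3 (`Cc1ccccc1C(=O)NNC(=O)c1cccc(NS(=O)(=O)c2cnc(O)nc2O)c1`) is next. The change from compound 1 is (2-methylphenyl)carbonyl in place of 3-chlorophenyl on an amine nitrogen. Among the compounds with values here, no step between measured compounds is available to size this change, and the only anchor is compound 1 at 8040 nM. In this assay, the expected step of a 1.4-fold higher number from compound 1 to compound 3 (0.14 log units; within the scatter) is small and toward weaker inhibition, and it may not exceed the usual scatter. A result reported only as a limit would not be surprising. For compound 3 the estimated value is 11000 nM, with an expected range of 4000 nM to 30000 nM.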

Compound 3, half-maximal inhibitory concentration: > 20000 nM
Compound 3 gave a limit, no number; the forecaster's own chance of this, stated with the estimate: 35%; middle value at least 1.8-fold (0.25 log units) away from the limit.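

Placing (2-methylphenyl)carbonyl in place of 3-chlorophenyl on this amine nitrogen gives the first sized step in the series: in this assay, the change gives an at least 2.4-fold higher number from compound 1 to compound 3 (0.39 log units; beyond the scatter). Compound 3 is recorded at > 20000 nM, which is a limit of the assay and not a number, so the step has a lower bound but no known full size. Compound 1 remains the only compound with an actual number, and the weak end of the series is now defined by a recurring limit: the limit of > 20000 nM in this assay, at which 2 of the 3 values shown sit.

The step changes both the carbonyl and the ring substituents, and the compounds shown do not separate the two. Also open, as far as these compounds go, is how an unsubstituted phenyl, or a phenyl carrying an amine or a carboxylic acid, would read out on this amine nitrogen.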